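The compounds below may be only part of what the source reports. "The series", "measured", "known", "first", "only" and "open" are said of these compounds alone.

Measured so far:
Compound 1, `CC1=C(C(=O)Nc2ccc(Br)cc2)C(c2ccccc2)NC(=O)N1`: > 100000 nM
Compound 2, `CC1=C(C(=O)Nc2ccccc2Cl)C(c2cccc(Br)c2)NC(=O)N1`: > 100000 nM

Both measured compounds share the same core and differ from each other at two aryl positions. In an ADME assay on Vero cells (Chlorocebus sabaeus) for cytotoxicity, read by XTT assay, with a stated time of 72 h (on this read-out lower numbers stand for higher toxicity in this test and higher numbers for lower toxicity in this test), compound 1 gives > 100000 nM, which is a limit of the assay rather than a number. In this assay compound 2 likewise gives > 100000 nM, again a limit and not a number. Compound 2 therefore stands at the limit of > 100000 nM in this assay, at which 2 of the 2 values shown sit. On the numbers shown, nothing separates compound 2 from compound 1, and no measured step exists to size any single change.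

Compound 3, `CC1=C(C(=O)Nc2ccccc2Cl)C(c2cccc([N+](=O)[O-])c2)NC(=O)N1`, differs from compound 2 in one place: nitro in place of bromo on an aromatic carbon. With both measured values sitting at a limit, no direction is indicated for this change. In this assay the expected step is a number no higher from compound 2 to compound 3 (the limit leaves the size open), that is, none beyond the usual scatter in either direction. Compound 3 is accordingly expected to give 100000 nM, with a range from 30000 nM to 300000 nM, and is most likely to be reported again only as a limit.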

Compound 3, half-maximal cytotoxic concentration: "non-toxic" (no number reported)
For compound 3 the study gives words and no number; the estimate stays without a comparison.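

For compound 3 the study reports only the words "non-toxic", with no number, so no step can be read between compound 2 and compound 3. The compounds shown leave open how far any single change on the shared core moves the half-maximal cytotoxic concentration in this assay, where the measured values stop at a limit: the limit of > 100000 nM in this assay, at which 2 of the 3 values shown sit.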